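This account rests on a few compounds, and the source may have more. Where it says the series, first, only, none or still open, it means among the compounds named here.

Compound 1 (`CCCCCCOc1cc(OC)c(Br)cc1C(C)=O`): 34000000 nM
Compound 2 (`CCCCCCCCCCOc1cc(OC)c(Br)cc1C(C)=O`): 15000000 nM
Compound 3 (`CCCCCCCCCCCCOc1cc(OC)c(Br)cc1C(C)=O`): not yet measured

In a functional assay, with stated times of 30 s and 6 min, in the presence of a further agent that is not named here (on this read-out lower numbers stand for stronger inhibition and higher numbers for weaker inhibition), compound 2 gives the lower of the two numbers, 15000000 nM. The change to compound 3 is ethyl in place of hydrogen on a saturated chain carbon, ten or more bonds along the chain from an oxygen on an aromatic ring. Within the data shown here, only one measured step bears on this: butyl in place of hydrogen, a 2.3-fold lower number from compound 1 to compound 2 (0.36 log units; beyond the scatter), modest and beyond the scatter. A single step shows no trend, so only a smaller move in the same direction is expected in this assay. The expected step is a 1.5-fold lower number from compound 2 to compound 3 (0.18 log units; within the scatter). For compound 3 the estimated value is 10000000 nM, with an expected range of 4000000 nM to 25000000 nM.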

Compound 3, half-maximal inhibitory concentration: 10600000 nM
Compound 3: middle estimate off by 1.1-fold (0.03 log units), on the low side; the range from low to high includes it.
By their numbers in this assay, from the lowest: compounds 3 and 2 (each within the scatter of the next); then compound 1.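

In this assay, ethyl in place of hydrogen on a saturated chain carbon, ten or more bonds along the chain from an oxygen on an aromatic ring, gives a 1.4-fold lower number from compound 2 to compound 3 (0.15 log units; within the scatter), so this extension does not separate the two compounds. Across the full change, hexyl in place of hydrogen gives a 3.2-fold lower number from compound 1 to compound 3 (0.51 log units; beyond the scatter), which remains a modest step. No measured evidence accounts for these results.

From the compounds shown here alone, whether a longer chain would produce a step beyond the scatter remains open. So does the effect of an amine or a carboxylic acid on this chain.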